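The source may report more compounds than this note shows. Statements on the series, on what has been measured and on what is new or still open speak of the compounds shown alone.

Working notes on the series. Going by the values given here, compound 2 `OC[C@H]1O[C@@H](n2cnc3c(Sc4ccccc4)ncnc32)[C@H](O)[C@@H]1O` gives 91200 nM in an assay on isolated protein for binding affinity to Equilibrative nucleoside transporter 1 (Homo sapiens) (on this read-out higher numbers stand for weaker inhibition and lower numbers for stronger inhibition), the highest of the two numbers so far; the nearest is compound 1 `OC[C@H]1O[C@@H](n2cnc3c(SC4CCCCC4)ncnc32)[C@H](O)[C@@H]1O`, which gives 6310 nM. Among the compounds with values here, the one measured step, a 14-fold higher number from compound 1 to compound 2 (1.16 log units; beyond the scatter), covers the change 3-methylbenzyl in place of phenyl on a sulfur only in part, since it swaps phenyl for cyclohexyl rather than lengthening the link. Compound 3 `Cc1cccc(CSc2ncnc3c2ncn3[C@@H]2O[C@H](CO)[C@@H](O)[C@H]2O)c1` is not yet measured. A lower number than for compound 2 is expected, with wide uncertainty, amounting to an estimated step of a 180-fold lower number from compound 2 to compound 3 (2.26 log units; beyond the scatter). The expected value for compound 3 is 500 nM, within 50 nM to 8000 nM.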

Compound 3, half-maximal inhibitory concentration: 12000 nM
The estimate for compound 3 lay 24-fold (1.38 log units) below the measured number; the whole stated range lies below it.
By their numbers in this assay, from the lowest: compounds 1 and 3 (each within the scatter of the next); then compound 2.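

Replacing phenyl with 3-methylbenzyl on the sulfur gives a 7.6-fold lower number from compound 2 to compound 3 (0.88 log units; beyond the scatter), so an aromatic ring at this position does not by itself hold the number at the level of compound 2. Replacing cyclohexyl with 3-methylbenzyl gives a 1.9-fold higher number from compound 1 to compound 3 (0.28 log units; within the scatter), so these two groups are not told apart here. No available evidence bears on the reason for either step.

As far as these compounds go, the longer link and the ring methyl enter together, so their shares in the step remain open. Plain benzyl would separate them, and 2-phenylethyl would test a still longer link.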